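This account rests on a few compounds, and the source may have more. Where it says the series, first, only, none or still open, it means among the compounds named here.

Of the compounds shown here, three in this set have so far been measured in a physicochemical assay for lipophilicity, at pH 7.4 (a higher number here means a more lipophilic compound, a lower number a more polar compound), and give a first view of the scale. Compound 1 `COc1cccc(C(=O)NCc2c(C)cc(C)[nH]c2=O)c1F` stands at 1.4 on that scale. Compound 3 `COc1ccc2c(c1Cl)C(=O)N(Cc1c(C)cc(C)[nH]c1=O)CCO2` reads 1.3 and so lies within the scatter of compound 1. Compound 2 `Cc1cc(C)c(CN2CCc3c(F)cc(O[C@@H]4CCOC4)c(Cl)c3C2=O)c(=O)[nH]1` reads 2.1 and stands clearly higher than both. Among the measured compounds shown here, compound 2 and compound 3 each differ from compound 1 in more than one place, so no measured pair here shows what a single swap does.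

Compound 4 `COc1cccc(C(=O)NCc2c(C)cc(C)[nH]c2=O)c1Cl`, not yet measured, differs from compound 1 by one change chloro in place of fluoro on an aromatic carbon and this change sits ortho to a large group and ortho to a methoxy group. General experience with this swap suggests a modest upward step in this assay from the 1.4 of compound 1. The estimated change is a number 0.40 log units higher from compound 1 to compound 4 (beyond the scatter) and remains only an expectation. For compound 4 the expected value is 1.8 with an estimated range from 1.4 to 2.2 until a measurement is available.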

Compound 4, distribution coefficient: 1.2
Estimate against measurement, compound 4: 0.60 log units above; the measured number lies below the stated range.
By their numbers in this assay, from the lowest: compounds 4, 3 and 1 (each within the scatter of the next); then compound 2.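

Among the compounds shown here, compound 1 and compound 4 form the first pair in this set that differs in one place only, so the effect of a single swap can now be read directly. Chloro in place of fluoro on this aromatic carbon, ortho to a large group and ortho to a methoxy group, gives a number 0.20 log units lower from compound 1 to compound 4 (within the scatter) in this assay and so leaves the two groups indistinguishable at this position in this assay. Nothing available here explains this result.

From the compounds shown here alone, whether a nitrile or an amine on the same carbon would give a step beyond the scatter remains open. So does whether chloro in place of fluoro would give a similar step elsewhere on the ring or on a different core.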